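A few compounds are considered here, and "the series" means these few. Any claim that something is new, unique, unknown or untested is made for them only; others in the source may bear on it.

Measured compounds:
compound 1 `CCCn1c(=O)[nH]c2nc(-c3ccc(S(=O)(=O)N4CCN(c5cccc(Br)c5)CC4)cc3)[nH]c2c1=O` — in an assay on CHO cells for displacement of a labelled ligand from adenosine receptor A3 (Homo sapiens), read by scintillation counting, with a stated time of 45 min, tested at 1 uM, in the presence of a further agent that is not named here (on this read-out higher numbers stand for more inhibition at the one concentration tested (going by the name of the read-out) and lower numbers for less inhibition), compound 1 gives 27%
compound 2 `CCCn1c(=O)[nH]c2nc(-c3ccc(S(=O)(=O)N4CCN(c5ccccc5Br)CC4)cc3)[nH]c2c1=O` — compound 2 gives 20%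
compound 3 `CCCn1c(=O)[nH]c2nc(-c3ccc(S(=O)(=O)N4CCN(c5ccccc5Cl)CC4)cc3)[nH]c2c1=O` — compound 3 gives 32%

Compound 2 has the lowest of the three numbers in this assay. Its nearest neighbour is compound 1, reached by a number 7 percentage points lower from compound 1 to compound 2 (within the scatter), which is within the scatter; its furthest is compound 3, reached by a number 12 percentage points higher from compound 2 to compound 3 (beyond the scatter), a modest step beyond the scatter. All three compounds share the same core and differ only in the group on the amine nitrogen in the ring.

Compound 4 `CCCn1c(=O)[nH]c2nc(-c3ccc(S(=O)(=O)N4CCN(Cc5cccc(C)c5)CC4)cc3)[nH]c2c1=O` has not yet been measured. It differs from compound 2 in one place: 3-methylbenzyl in place of 2-bromophenyl on an amine nitrogen in a ring.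

Within the data shown here, two measured steps touch the same ring nitrogen. The step of a number 7 percentage points lower from compound 1 to compound 2 (within the scatter) moves a bromine between two positions of the phenyl and stays within the scatter; the step of a number 12 percentage points higher from compound 2 to compound 3 (beyond the scatter) swaps a halogen and gives a modest rise. Among the measured compounds shown here, neither step replaces the aryl group by a benzyl group, and no measured compound carries a methyl on that ring, so the change to compound 4 is not directly covered. Compound 2 sits at the low end of a narrow spread, so the expected step of a number 6 percentage points higher from compound 2 to compound 4 (within the scatter) is small and probably not beyond the scatter. Compound 4 is therefore estimated at 26%, with a range from 8% to 44%.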

Compound 4, a percentage reported as inhibition, at one concentration (the size of the read-out at that concentration, not a potency): 17%
Compound 4: middle estimate off by 9 percentage points, on the high side; the range from low to high includes it.
By their numbers in this assay, from the lowest: compounds 4, 2, 1 and 3 (each within the scatter of the next, the first and the last beyond it).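

In this assay, among these compounds, 3-methylbenzyl on the amine nitrogen in the ring is the first group at this position that is a benzyl rather than a phenyl and that carries a methyl rather than a halogen, yet this double change gives a number 3 percentage points lower from compound 2 to compound 4 (within the scatter) and a number 10 percentage points lower from compound 1 to compound 4 (within the scatter), so it cannot be told apart from either bromophenyl group. Among the compounds shown here, only against the 2-chlorophenyl group does the change stand out, with a number 15 percentage points lower from compound 3 to compound 4 (beyond the scatter), a modest fall that makes compound 3 the only compound from which the new group is clearly separated. Nothing measured here accounts for these steps.

The compounds shown leave open how much of that one modest fall belongs to the added benzyl carbon and how much to the exchange of halogen for methyl, a question that a plain benzyl group or a 3-chlorobenzyl group at the same nitrogen would address. They also leave open whether a non-aromatic group on this nitrogen, such as a longer alkyl chain or one ending in a carboxylic acid, would move the number beyond this narrow spread.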